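Swapping Acetyl for Dimethylamino on a Weak Pair

The source may report more compounds than this note shows. Statements on the series, on what has been measured and on what is new or still open speak of the compounds shown alone.

Compound 1 `COc1cc(C)cc(-c2c(-c3ccnc(-c4ccc(C(C)=O)cc4)c3)cnn2CC#N)c1` was tested in a functional assay on COLO 205 cells (Homo sapiens) for cytotoxicity, read by sulforhodamine B assay, with a stated time of 48 h, tested at 0.01 uM (a higher number here means a weaker effect of the compound at the concentration tested, a lower number a stronger effect), where compound 1 gives 102%, the highest of the two numbers available. Compound 2 `Cc1cc(O)cc(-c2nn(CC#N)cc2-c2ccnc(-c3ccc(N(C)C)cc3)c2)c1` gives 95% in this assay, a difference within the scatter, so the two show no order. Compound 3 `COc1cc(C)cc(-c2c(-c3ccnc(-c4ccc(N(C)C)cc4)c3)cnn2CC#N)c1` awaits measurement. It differs from compound 1 in one place: dimethylamino in place of acetyl on an aromatic carbon. Going by the values given here, no step between measured compounds exists to guide the expectation, but compound 2 already carries dimethylamino and gives 95%. The expected step of a number 4 percentage points lower from compound 1 to compound 3 (within the scatter) is therefore none beyond the scatter. Compound 3 is estimated at 98%, between 86% and 108%.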

Compound 3, a percentage reported as activity, at one concentration (the size of the read-out at that concentration, not a potency): 72%
Compound 3: the middle estimate sits 26 percentage points above what was measured, outside the stated range (below it).
By their numbers in this assay, from the lowest: compound 3; then compounds 2 and 1 (each within the scatter of the next).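

In this assay, going by these compounds alone, dimethylamino in place of acetyl gives a number 30 percentage points lower from compound 1 to compound 3 (beyond the scatter), the first step here beyond the scatter, so the number responds to a change at this position. Both groups count the same heavy atoms and hydrogen-bond acceptors, so these counts alone do not separate them. No measurement available here explains the step.

Going by these compounds, whether a primary amine or a carboxylic acid at the same place would move the number further, and in which direction, stays open. The read-out also comes from one concentration, so it shows only a stronger or weaker effect of these compounds at that concentration.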